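Swapping the Aryl Group and Expected Liver Clearance

The source may hold more compounds than are shown below. What is called first, only, known or untested is meant among the compounds shown, and "the series" means these compounds.

Going by the values given here, compound 2 `NC(=O)c1cccc(-c2cc(C(O)(C(F)(F)F)C(F)(F)F)cnc2N2CCN(S(=O)(=O)c3ccc(N)nc3)CC2)c1` gives 63 mL.min-1.g-1 in an ADME assay (liver) for metabolic stability, with Liver microsome (Rattus norvegicus) as the target, using microsomes and NADPH, with a stated time of 30 min, tested at 1 uM (on this read-out lower numbers stand for slow clearance and higher numbers for fast clearance), the lowest of the two numbers measured so far; compound 1 `CC(C)n1cc(-c2cc(C(O)(C(F)(F)F)C(F)(F)F)cnc2N2CCN(S(=O)(=O)c3ccc(N)nc3)CC2)cn1` gives 198 mL.min-1.g-1, and the change was a 3.1-fold lower number from compound 1 to compound 2 (0.50 log units; beyond the scatter). Compound 3 `Nc1ccc(S(=O)(=O)N2CCN(c3ncc(C(O)(C(F)(F)F)C(F)(F)F)cc3-c3ccc4ocnc4c3)CC2)cn1` has not been measured. It differs from compound 2 by 1,3-benzoxazol-5-yl in place of 3-carbamoylphenyl on an aromatic carbon. Among the compounds with values here, only the step from compound 1 to compound 2 bears on this, and it shows that replacing this aryl group can move the read-out modestly. The estimate for compound 3 is 120 mL.min-1.g-1, within 50 mL.min-1.g-1 to 300 mL.min-1.g-1, an expected step of a 1.9-fold higher number from compound 2 to compound 3 (0.28 log units; within the scatter).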

Compound 3, intrinsic clearance in microsomes: 120 mL.min-1.g-1
Compound 3: the middle estimate sits on the measured number at the digits printed, and the stated range covers the measured number.
By their numbers in this assay, from the lowest: compounds 2, 3 and 1 (each within the scatter of the next, the first and the last beyond it).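

In this assay, the 1,3-benzoxazol-5-yl group cannot be told apart from either earlier group at this position: the steps are a 1.9-fold higher number from compound 2 to compound 3 (0.28 log units; within the scatter) and a 1.7-fold lower number from compound 1 to compound 3 (0.22 log units; within the scatter). So this position now carries three different ring groups, and only compound 1 and compound 2 stand apart beyond the scatter. Nothing measured here explains these numbers. As far as these compounds go, whether an open-chain amine or a carboxylic acid on this aromatic carbon would give a number clearly apart from all three remains open.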